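A few compounds are considered here, and "the series" means these few. Any claim that something is new, unique, unknown or untested is made for them only; others in the source may bear on it.

Measured so far in a functional assay on DU-145 cells (Homo sapiens) for cytotoxicity, read by MTT assay, with a stated time of 48 h; a higher number here means a weaker inhibitor, a lower number a stronger inhibitor:
- Compound 1 `CC(C)=CCC/C(C)=C/CC/C(C)=C/CC[C@@H]1[C@@]2(C)CC/C(=N\OCc3cn(-c4cccc(C(F)(F)F)c4)nn3)C(C)(C)[C@@H]2CC[C@@]1(C)O` gives 11800 nM
- Compound 2 `CC(C)=CCC/C(C)=C/CC/C(C)=C/CC[C@@H]1[C@@]2(C)CC/C(=N\OCc3cn(-c4cccc(O)c4)nn3)C(C)(C)[C@@H]2CC[C@@]1(C)O` gives 17500 nM
- Compound 3 `CC(C)=CCC/C(C)=C/CC/C(C)=C/CC[C@@H]1[C@@]2(C)C/C(=C\c3ccc(OCc4cn(-c5cccc(C(F)(F)F)c5)nn4)cc3)C(=O)C(C)(C)[C@@H]2CC[C@@]1(C)O` gives 9330 nM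

Compound 2 differs from compound 1 in one place: hydroxy in place of trifluoromethyl on an aromatic carbon. In this assay this change gave a 1.5-fold higher number from compound 1 to compound 2 (0.17 log units; within the scatter), so the two values are not told apart by the measurement. Compound 3 is built on a different core; the difference between the two cores is not broken down here. Its value and those of compound 1 and compound 2 all lie within the usual scatter of one another, so no order among the three can be read.

Compound 4 `CC(C)=CCC/C(C)=C/CC/C(C)=C/CC[C@@H]1[C@@]2(C)C/C(=C\c3ccc(OCc4cn(-c5cccc(O)c5)nn4)cc3)C(=O)C(C)(C)[C@@H]2CC[C@@]1(C)O` has not yet been measured. It differs from compound 3 by hydroxy in place of trifluoromethyl on an aromatic carbon, the same change made from compound 1 to compound 2, sitting in surroundings described in the same words. Because that earlier change gave a 1.5-fold higher number from compound 1 to compound 2 (0.17 log units; within the scatter), the step from compound 3 to compound 4 is expected to be similarly small, a 1.4-fold higher number from compound 3 to compound 4 (0.14 log units; within the scatter), though a single precedent is a thin basis. Compound 4 is thus expected near 13000 nM, most likely between 6000 nM and 30000 nM.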

Compound 4, half-maximal inhibitory concentration: 40600 nM
Compound 4: middle estimate off by 3.1-fold (0.49 log units), on the low side, and the stated range ends below it.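

In this assay, putting hydroxy in place of trifluoromethyl on the core of compound 3 gave a 4.4-fold higher number from compound 3 to compound 4 (0.64 log units; beyond the scatter), so on this core the change can be told apart from measurement noise. The same change therefore does not carry over at the same size from one core to the other, and a step measured on one core proved a poor guide to the step on the other: the same change on two cores in this assay, a 1.5-fold higher number (0.17 log units; within the scatter) from compound 1 to compound 2 and a 4.4-fold higher number (0.64 log units; beyond the scatter) from compound 3 to compound 4, 2.9-fold (0.47 log units) apart, beyond the scatter of two such steps

For the compounds shown here, with only two matched pairs, this shows that the size of the step differed between these two cores, but not which structural difference between them is responsible, and it offers no rule for any further core.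

The compounds shown carry only trifluoromethyl or hydroxy on the aromatic ring, so it remains open how a methoxy group, an amine or a carboxylic acid in the same place would behave on either core. As far as these compounds go, it also remains open whether the gap between the two steps would persist with such groups, or whether it is particular to this one pair of substituents.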